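This account rests on a few compounds, and the source may have more. Where it says the series, first, only, none or still open, it means among the compounds named here.

Of the compounds shown here, three that share one core have been measured in a functional assay on PC-3 cells (Homo sapiens) for inhibition, read by MTT assay, with a stated time of 48 h, tested at 10 uM; a higher number here means more inhibition of growth at the concentration tested, a lower number less inhibition of growth. There, compound 1 (`Cc1cc(=O)c2c(O)cc(OC/C=C/c3ccccc3)c([C@H]3CCN(C)C[C@H]3O)c2o1`) gives 18%, compound 2 (`Cc1cc(=O)c2c(O)c(CN3CCCC3C(=O)O)c(O)c([C@H]3CCN(C)C[C@H]3O)c2o1`) gives 0% and compound 3 (`Cc1oc2c([C@H]3CCN(C)C[C@H]3O)c(O)cc(O)c2c(=O)c1C(O)c1cccc(Cl)c1`) gives 31%. Compound 3 therefore stands highest of the three, and its gaps to both of the others lie beyond the scatter, although even this value is a modest one.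

Compound 4 (`Cc1oc2c([C@H]3CCN(C)C[C@H]3O)c(O)cc(O)c2c(=O)c1C(O)c1cc(F)cc(F)c1`) has not yet been measured. It differs from compound 3 in a single place, with 3,5-difluorophenyl in place of 3-chlorophenyl on a saturated chain carbon bound to an aromatic carbon and an oxygen on a saturated carbon. The rest of the structure is unchanged. Within the data shown here, no two measured compounds differ in only one place, which leaves the data without a direct precedent for this exchange. Each group is one six-membered aromatic ring of carbon only, with no hydrogen-bond donors, no hydrogen-bond acceptors and no net charge.

No change beyond the scatter is expected in this assay, and neither direction is favoured, with compound 3 at 31% as the reference. The expected size of the step is a number 3 percentage points lower from compound 3 to compound 4 (within the scatter). For compound 4 the estimated value is 28%, with an expected range of 13% to 44%.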

Compound 4, percent growth inhibition at one concentration: 0%
Compound 4: middle estimate off by 28 percentage points, on the high side; the whole stated range lies above it.
By their numbers in this assay, from the lowest: compounds 2 and 4 (each within the scatter of the next); then compound 1; then compound 3.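

In this assay, among these compounds, the exchange of 3-chlorophenyl for 3,5-difluorophenyl on a saturated chain carbon bound to an aromatic carbon and an oxygen on a saturated carbon gives a number 31 percentage points lower from compound 3 to compound 4 (beyond the scatter), the first comparison in this set in which only one place changes. It shows that this position is not indifferent to what the aromatic ring carries, even though both groups are one six-membered aromatic ring of carbon only, with no hydrogen-bond donors or acceptors and no net charge. Compound 4 keeps the shared core and the hydroxy-bearing carbon, so these parts alone do not secure growth inhibition at the concentration tested, and nothing available here explains the loss.

The compounds shown leave open whether the loss follows from the chlorine leaving, from the fluorines entering, or from both together, as this single exchange does all of this at once. A plain phenyl, a fluorophenyl or a dichlorophenyl at this place would begin to separate those possibilities, and an amine or a carboxylic acid on the ring would test how far the position tolerates a different kind of group.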